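Swapping the five-membered ring on an imidazoline-bearing biphenyl

The source may report more compounds than this note shows. Statements on the series, on what has been measured and on what is new or still open speak of the compounds shown alone.

Measured compounds:
- compound 1 `c1c[nH]c(-c2ccccc2OCC2=NCCN2)c1`: 111%
- compound 2 `c1ccc(-c2ccoc2)c(OCC2=NCCN2)c1`: 126%

Both compounds were tested in a functional assay with Alpha-1D adrenergic receptor (Homo sapiens) as the target, read by calcium flux; on this read-out higher numbers stand for larger maximal responses and lower numbers for smaller maximal responses. Within the data shown here, compound 1 gives 111%, and compound 2 gives 126%, so compound 2 stands highest of the two numbers; the only measured step, a number 15 percentage points higher from compound 1 to compound 2 (beyond the scatter), lies beyond the scatter.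

Compound 3 `c1ccc(-c2ccns2)c(OCC2=NCCN2)c1` has not yet been measured. It differs from compound 2 in one place: 1,2-thiazol-5-yl in place of furan-3-yl on an aromatic carbon. The measured step concerns a different exchange on the same carbon, pyrrole against furan, and nothing measured bears directly on furan against 1,2-thiazole. Among the measured compounds shown here, the only guide is that the exchange of one five-membered aromatic ring for another shifted the response only modestly. Compound 3 is therefore expected to stay close to compound 2, with a step of a number 6 percentage points lower from compound 2 to compound 3 (within the scatter) that need not exceed the scatter. The estimate for compound 3 in this assay is 120%, within a range from 100% to 140%.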

Compound 3, largest response reached (reported as maximum), in percent of the reference or control that the assay uses: 82%
The estimate for compound 3 lay 38 percentage points above the measured number; the measured number lies below the stated range.
By their numbers in this assay, from the lowest: compound 3; then compound 1; then compound 2.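

In this assay, the choice of five-membered aromatic ring on this carbon matters more than the first exchange suggested: 1,2-thiazol-5-yl in place of furan-3-yl gives a number 44 percentage points lower from compound 2 to compound 3 (beyond the scatter) and, in place of 1H-pyrrol-2-yl, gives a number 29 percentage points lower from compound 1 to compound 3 (beyond the scatter) in the same direction. Rings of equal heavy-atom count are thus not interchangeable at this position, and compound 3 lies beyond the scatter from both other compounds, at the low end of the three. No available evidence accounts for this fall.

With the sulfur, the ring nitrogen and the point of attachment all changing together, the compounds shown cannot say which of these goes with the fall. On these data alone, how an amine or a carboxylic acid on the same carbon would compare also remains open.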